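Aryl on the ring amide nitrogen: compound 3 to compound 4

The compounds below may be only part of what the source reports. "The series", "measured", "known", "first", "only" and "open" are said of these compounds alone.

In a functional assay on HOS-TE85 cells (Homo sapiens) for inhibition, read by CCK-8 assay, with a stated time of 72 h (a higher number here means a weaker inhibitor, a lower number a stronger inhibitor), compound 1 `CC(C)(C)c1conc1N1C(=O)CSC1c1cccc(C(=O)NCCCCc2ccccc2)c1` gives only the assay limit > 1000 nM.
Compound 2 `O=C(NCCCCc1ccccc1)c1cccc(C2SCC(=O)N2c2ccccn2)c1` gives 19.7 nM in this assay.
Compound 3 `COc1cccc(OC)c1N1C(=O)CSC1c1cccc(C(=O)NCCCCc2ccccc2)c1` gives only the assay limit > 1000 nM in this assay.

Compound 3 thus stands at the weak end of the series, where (the limit of > 1000 nM in this assay, at which 2 of the 3 values shown sit); it yields no number. Compound 4 `O=C(NCCCCc1ccccc1)c1cccc(C2SCC(=O)N2c2cccc(F)c2)c1` carries 3-fluorophenyl in place of 2,6-dimethoxyphenyl on an amide-type nitrogen in a ring. Within the data shown here, the steps that bear on this change are an at least 50-fold higher number from compound 2 to compound 3 (1.70 log units; beyond the scatter) and an at least 50-fold lower number from compound 1 to compound 2 (1.70 log units; beyond the scatter), both large; a step that the two limits leave unreadable from compound 1 to compound 3 is unreadable. In both readable steps the small six-membered aromatic ring on that nitrogen gives the low number, and 3-fluorophenyl is again a small six-membered aromatic ring. A large step down in this assay is therefore expected, an at least 16-fold lower number from compound 3 to compound 4 (1.22 log units; beyond the scatter). Compound 4 is expected to give 60 nM in this assay, estimated between 12 nM and 500 nM.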

Compound 4, half-maximal inhibitory concentration: 32.4 nM
Compound 4: the middle estimate sits 1.9-fold (0.27 log units) above what was measured; the range from low to high includes it.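

On the amide-type ring nitrogen, a carbon-only six-membered aromatic ring can hold the low number in this assay, so a ring nitrogen in that group is not required: a 1.6-fold higher number from compound 2 to compound 4 (0.22 log units; within the scatter). A carbon-only aromatic ring does not by itself set the outcome, since 3-fluorophenyl and 2,6-dimethoxyphenyl share that ring type, yet an at least 30-fold lower number from compound 3 to compound 4 (1.48 log units; beyond the scatter), and the group of compound 1 also falls far behind, with an at least 30-fold lower number from compound 1 to compound 4 (1.48 log units; beyond the scatter). Compound 1 and compound 3 give only assay limits, not numbers: the limit of > 1000 nM in this assay, at which 2 of the 4 values shown sit.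

Open, as far as these compounds go, is whether a single methoxy group, 3-aminophenyl or 3-carboxyphenyl on that nitrogen keeps the low number.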